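The source may report more compounds than this note shows. Statements on the series, on what has been measured and on what is new or still open speak of the compounds shown alone.

Three compounds share one core and differ only in the group on an aromatic nitrogen. Compound 1 `CCC(CC)n1c(-c2ccc(OCc3c(-c4c(Cl)cccc4Cl)noc3C(C)C)cc2)nc2ccc(C(=O)O)cc21` carries pentan-3-yl there, and in an assay on HEK-293T cells for antagonist activity at vitamin D3 receptor (Homo sapiens), read by a luciferase reporter, with a stated time of 24 h (a lower number here means a stronger inhibitor, a higher number a weaker inhibitor), compound 1 gives 5690 nM. Compound 2 `CCn1c(-c2ccc(OCc3c(-c4c(Cl)cccc4Cl)noc3C(C)C)cc2)nc2ccc(C(=O)O)cc21` carries ethyl, and in this assay compound 2 gives 5760 nM. Compound 3 `CCCC(CCC)n1c(-c2ccc(OCc3c(-c4c(Cl)cccc4Cl)noc3C(C)C)cc2)nc2ccc(C(=O)O)cc21` carries 1-propylbutyl. For compound 3 this assay reports only a limit, > 10000 nM; this is the limit of > 10000 nM in this assay, at which 1 of the 3 values shown sits. Compound 3 thus stands at the weak end of what is recorded and has no number of its own. The measured steps are a 1.0-fold higher number from compound 1 to compound 2 (0.01 log units; within the scatter), an at least 1.7-fold higher number from compound 1 to compound 3 (0.24 log units; that floor lies within the scatter) and an at least 1.7-fold higher number from compound 2 to compound 3 (0.23 log units; that floor lies within the scatter); none of them reaches beyond the scatter.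

Compound 4 `CC(C)c1onc(-c2c(Cl)cccc2Cl)c1COc1ccc(-c2nc3ccc(C(=O)O)cc3n2CC2CC2)cc1` is not yet measured. The change from compound 3 is cyclopropylmethyl in place of 1-propylbutyl on an aromatic nitrogen. All three measured steps exchange one alkyl group for another on this same nitrogen, and none of them moved this assay beyond the scatter, so a change of similar size, or none at all, is expected here. Since compound 3 sits at a limit, the step that this expectation implies is an at least 1.4-fold lower number from compound 3 to compound 4 (0.15 log units; that floor lies within the scatter). Compound 4 is estimated at 7000 nM, with a range from 3000 nM to 16000 nM.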

Compound 4, half-maximal inhibitory concentration: 2650 nM
The estimate for compound 4 lay 2.6-fold (0.42 log units) above the measured number; the whole stated range lies above it.
By their numbers in this assay, from the lowest: compound 4; then compounds 1 and 2 (each within the scatter of the next). At a limit, above all of these: compound 3.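

Among the compounds shown here, on this aromatic nitrogen, cyclopropylmethyl moves this assay beyond the scatter, which no exchange among the earlier alkyl groups did, with a 2.2-fold lower number from compound 2 to compound 4 (0.34 log units; beyond the scatter) and a 2.1-fold lower number from compound 1 to compound 4 (0.33 log units; beyond the scatter); since ethyl and pentan-3-yl cannot be told apart, and cyclopropylmethyl, the only group here with a ring, gives the lowest number of the four, the read-out does not simply follow the size of the group. Against the largest group, 1-propylbutyl, the change gives an at least 3.7-fold lower number from compound 3 to compound 4 (0.57 log units; beyond the scatter). Compound 3 has only a limit of the assay, so this step is a floor and its true size stays unknown: the limit of > 10000 nM in this assay, at which 1 of the 4 values shown sits.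

The compounds shown leave open whether the three-membered ring itself matters or whether another ring would serve as well, as cyclobutylmethyl, or cyclopropyl set on the aromatic nitrogen, could show. They also leave open how this assay would respond to a chain that carries an amine or an ether oxygen at this position.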